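Methyl for hydrogen: what compound 4 is expected to give

The compounds below may be only part of what the source reports. "The series", "measured", "known", "first", "only" and "open" are said of these compounds alone.

Of the compounds shown here, three built on one shared core have been measured in a functional assay (Platelet, plasma) for inhibition, with Homo sapiens as the target; on this read-out lower numbers stand for stronger inhibition and higher numbers for weaker inhibition. Compound 1 `N#Cc1cc2c(nc1N1CCC(C(=O)NS(=O)(=O)c3ccc(Cl)s3)CC1)COC2=O` gives 4470 nM in this assay. Compound 3 `N#Cc1cc2c(nc1N1CCC(C(=O)NS(=O)(=O)Cc3ccc(Cl)cc3)CC1)COC2=O` gives 4420 nM in this assay. The two differ in a single place: 5-chlorothiophen-2-yl in place of 4-chlorobenzyl on a sulfonyl sulfur. That change made a 1.0-fold lower number from compound 1 to compound 3 (0.00 log units; within the scatter). Compound 2 `CC1(C(=O)NS(=O)(=O)Cc2ccc(Cl)cc2)CCN(c2nc3c(cc2C#N)C(=O)OC3)CC1` gives 3010 nM in this assay; it differs from compound 3 in one place, (methyl in place of hydrogen on a saturated ring carbon), and that change made a 1.5-fold lower number from compound 3 to compound 2 (0.17 log units; within the scatter). None of the three can be called stronger or weaker than another on this read-out.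

Compound 4 `CC1OC(=O)c2cc(C#N)c(N3CCC(C(=O)NS(=O)(=O)c4ccc(Cl)s4)CC3)nc21` has not yet been measured in this assay. Against compound 1 it carries methyl in place of hydrogen on a saturated ring carbon. Going by the values given here, this is the same kind of change as the one from compound 3 to compound 2, but not the same change: there the methyl enters on a saturated ring carbon of a six-membered non-aromatic ring with 1 nitrogen, three ring bonds from the ring nitrogen and three ring bonds from the ring atom that bears a large group, whereas in compound 4 it enters on a saturated ring carbon of a five-membered non-aromatic ring with 1 oxygen, part of a fused or bridged system of two rings, next to the ring oxygen.

Because the same kind of change made a 1.5-fold lower number from compound 3 to compound 2 (0.17 log units; within the scatter), which lies within the scatter, compound 4 is expected to stay close to compound 1, with an expected step of a 1.2-fold lower number from compound 1 to compound 4 (0.09 log units; within the scatter). The estimate for compound 4 in this assay is 3600 nM, expected to fall between 1500 nM and 9000 nM.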

Compound 4, half-maximal inhibitory concentration: > 300000 nM
Compound 4: a limit, no number; the forecaster's own chance of this, stated with the estimate: 10%; at least 83-fold (1.92 log units) between middle value and limit.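

In this assay compound 4 gives > 300000 nM, which is a limit of the assay and not a number. Methyl in place of hydrogen gave an at least 67-fold higher number from compound 1 to compound 4 (1.82 log units; beyond the scatter), so in this series the result of the change on one core did not carry over to the other: the same change on two cores in this assay, a 1.5-fold lower number (0.17 log units; within the scatter) from compound 3 to compound 2 and an at least 67-fold higher number (1.82 log units; beyond the scatter) from compound 1 to compound 4, at least 98-fold (1.99 log units) apart, beyond the scatter of two such steps

What this does not show is the reason for the difference, since the two pairs differ in more than one respect: one methyl enters on a six-membered non-aromatic ring with 1 nitrogen and the other on a five-membered non-aromatic ring with 1 oxygen, while the sulfonyl sulfur carries 4-chlorobenzyl in one pair and 5-chlorothiophen-2-yl in the other, and with a single pair of each kind these factors cannot be separated.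

The compounds shown leave open whether methyl on the five-membered ring would give a similar step with 4-chlorobenzyl on the sulfonyl sulfur. They also leave open whether an ethyl or a hydroxymethyl group on that same ring carbon would behave as the methyl does.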